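The source may report more compounds than this note shows. Statements on the series, on what has been measured and on what is new or still open speak of the compounds shown alone.

Measured so far:
- Compound 1 `CC(C)c1ccc(-c2nc(CN3CCN(c4ccnc5cc(-c6cccnc6)ccc45)CC3)no2)cc1`: 76.5%
- Compound 2 `Cc1cccc(-c2nc(CN3CCN(c4ccnc5cc(-c6cccnc6)ccc45)CC3)no2)c1C`: 78%

In an ADME assay on microsomes from liver (Homo sapiens) for metabolic stability, read by LC-MS, with a stated time of 120 min, tested at 1 uM (a lower number here means that less of the compound is left, a higher number that more of the compound is left), compound 2 gives 78%, the higher of the two numbers, while compound 1 sits within the scatter of it, as the step of a number 1.5 percentage points higher from compound 1 to compound 2 (within the scatter) shows. The unmeasured compound 3 `c1cncc(-c2ccc3c(N4CCN(Cc5noc(C6CCCC6)n5)CC4)ccnc3c2)c1` changes compound 2 by cyclopentyl in place of 2,3-dimethylphenyl on an aromatic carbon. Within the data shown here, the only measured step swapped one six-membered aromatic ring for another and stayed within the scatter; no measured step replaces an aromatic ring with a cyclopentyl, so it gives only weak guidance. For compound 3 the expectation in this assay is a modest drop, a number 10 percentage points lower from compound 2 to compound 3 (within the scatter), with an estimate of 68% and a range from 48% to 85%.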

Compound 3, percent of the compound remaining: 97.8%
Compound 3: middle estimate off by 29.8 percentage points, on the low side; the measured number lies above the stated range.
By their numbers in this assay, from the lowest: compounds 1 and 2 (each within the scatter of the next); then compound 3.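

Among these compounds, at this position on the five-membered aromatic ring, this assay shows a change beyond the scatter for the first time: cyclopentyl gives a number 19.8 percentage points higher from compound 2 to compound 3 (beyond the scatter), and against 4-isopropylphenyl it gives a number 21.3 percentage points higher from compound 1 to compound 3 (beyond the scatter). Swapping one substituted six-membered aromatic ring for another had left the number within the scatter, whereas this non-aromatic carbon ring raises it with either aromatic group as the starting point. Nothing available here explains the rise.

The compounds shown leave open whether losing the aromatic ring or having fewer heavy atoms matters more. A cyclohexyl or a tert-butyl group at this position would help separate the two.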